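This account rests on a few compounds, and the source may have more. Where it says the series, first, only, none or still open, it means among the compounds named here.

Measured in a functional assay on MCF7 cells (Homo sapiens) for antiproliferative activity, read by MTT assay, with a stated time of 24 h; on this read-out lower numbers stand for stronger inhibition and higher numbers for weaker inhibition:
- compound 1 `CCCCc1oc2ccccc2c1C(=O)c1ccc(OCC(=O)NC(C)C)cc1`: > 50000 nM (a limit of the assay, not a number)
- compound 2 `CCCCc1oc2ccccc2c1C(=O)c1ccc(OCC(=O)Nc2cccc(OC)c2)cc1`: 38500 nM
- compound 3 `CCCCc1oc2ccccc2c1C(=O)c1ccc(OCC(=O)N[C@H](C)c2ccccc2)cc1`: 14100 nM

Compound 3 has the lowest number of the three, and its steps to both others lie beyond the scatter. Among the measured compounds shown here, its nearest neighbour is compound 2, the only other compound with an actual number.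

Compound 4 `CCCCc1oc2ccccc2c1C(=O)c1ccc(OCCCC(=O)N2CCOCC2)cc1` keeps the shared core and differs from compound 3 as follows: 2-((morpholin-4-yl)carbonyl)ethyl in place of (1-phenylethyl)carbamoyl on a saturated chain carbon bound to an oxygen on an aromatic ring. The six-membered aromatic ring of carbon only thus leaves, and a six-membered non-aromatic ring enters.

For the measured compounds named here, two measured steps bear on this change, both made on the amide-type nitrogen: an at least 3.5-fold lower number from compound 1 to compound 3 (0.54 log units; beyond the scatter) and a 2.7-fold lower number from compound 2 to compound 3 (0.44 log units; beyond the scatter). The first is the closer guide, since compound 1 also has no aromatic ring in that group. A third step, an at least 1.2-fold lower number from compound 1 to compound 2 (0.11 log units; that floor lies within the scatter), adds little, as its floor lies within the scatter. Going by the values given here, no measured step covers the 2-((morpholin-4-yl)carbonyl)ethyl group itself, so this is an extrapolation from three compounds.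

A modest loss of activity is therefore expected, and the expected step is a 2.8-fold higher number from compound 3 to compound 4 (0.45 log units; beyond the scatter). For compound 4 the estimate is 40000 nM, with an expected range from 15000 nM to 100000 nM, and the result may well be reported only as a limit.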

Compound 4, half-maximal inhibitory concentration: 41200 nM
Beside the measured number, compound 4's estimate is 1.0-fold (0.01 log units) below it, within the range that was stated.
By their numbers in this assay, from the lowest: compound 3; then compounds 2 and 4 (each within the scatter of the next). At a limit, above all of these: compound 1.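

Putting 2-((morpholin-4-yl)carbonyl)ethyl in place of (1-phenylethyl)carbamoyl gives a 2.9-fold higher number from compound 3 to compound 4 (0.47 log units; beyond the scatter) and leaves compound 3 the most active of the four, as its steps to all the others lie beyond the scatter. The new group has a six-membered non-aromatic ring and no hydrogen-bond donor, yet the comparison with (3-methoxyphenyl)carbamoyl gives a 1.1-fold higher number from compound 2 to compound 4 (0.03 log units; within the scatter) so an aromatic ring in this group does not by itself separate compound 2 from compound 4. The comparison with the isopropyl amide gives an at least 1.2-fold lower number from compound 1 to compound 4 (0.08 log units; that floor lies within the scatter) and this shows no real gain because compound 1 stands at a limit of the assay and has no actual number: the limit of > 50000 nM in this assay, at which 1 of the 4 values shown sits.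

Going by these compounds, it remains open whether a free carboxylic acid or a simple benzyl amide at this place would match compound 3 or fall back towards compound 2 and compound 4. Also open, on these data alone, is how the opposite configuration at the stereocentre of compound 3 would compare.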